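Removing one fluorine from a pentafluorophenyl ring

The source may hold more compounds than are shown below. What is called first, only, known or untested is meant among the compounds shown, and "the series" means these compounds.

Three compounds share one core and differ only in the aryl group hanging from the oxadiazole linker. Compound 3 `CC(C)(C)n1ncc(OCc2nnc(-c3ccccc3)o2)c(Cl)c1=O` carries a plain phenyl ring and gives 12.2 ug/mL in a functional assay on the whole organism for inhibition, with Mythimna separata as the target, with a stated time of 5 days; a higher number here means that more compound is needed for the effect, a lower number that less compound is needed. Compound 1 `CC(C)(C)n1ncc(OCc2nnc(-c3ccccc3Cl)o2)c(Cl)c1=O` carries a chloro on that ring and gives 61.2 ug/mL; the step of a 5.0-fold lower number from compound 1 to compound 3 (0.70 log units; beyond the scatter) shows that taking the chloro away lowered the number. Compound 2 `CC(C)(C)n1ncc(OCc2nnc(-c3c(F)c(F)c(F)c(F)c3F)o2)c(Cl)c1=O` carries five fluoro groups on the ring and gives 271 ug/mL, the highest of the three numbers, standing beyond the scatter from both compound 1 and compound 3.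

Compound 4 `CC(C)(C)n1ncc(OCc2nnc(-c3cc(F)c(F)c(F)c3F)o2)c(Cl)c1=O` is compound 2 with one change: hydrogen in place of fluoro on an aromatic carbon, at a position ortho to a fluoro group, ortho to a large group, meta to two fluoro groups and para to a fluoro group. Among the compounds with values here, the only measured step that bears on this is a 5.0-fold lower number from compound 1 to compound 3 (0.70 log units; beyond the scatter), where a halogen left the ring and the number fell. Compound 4 still keeps four fluoro groups, so a smaller move than that is expected. The expected step is a 2.3-fold lower number from compound 2 to compound 4 (0.35 log units; beyond the scatter), downward. Compound 4 is estimated at 120 ug/mL in this assay, within a range from 45 ug/mL to 320 ug/mL.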

Compound 4, half-maximal effective concentration: 241 ug/mL
Beside the measured number, compound 4's estimate is 2.0-fold (0.30 log units) below it; measured number inside the range.
By their numbers in this assay, from the lowest: compound 3; then compound 1; then compounds 4 and 2 (each within the scatter of the next).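

In this assay, replacing this one fluoro group with hydrogen gives a 1.1-fold lower number from compound 2 to compound 4 (0.05 log units; within the scatter), so the two compounds cannot be told apart by this measurement. This position, para to a fluoro group and ortho to a large group, therefore tolerates either atom without a measurable change while the other fluoro groups remain on the ring. The earlier step, a 5.0-fold lower number from compound 1 to compound 3 (0.70 log units; beyond the scatter), might have suggested that taking any halogen off the aryl ring lowers the number, but compound 4 goes against that reading: swapping a halogen for hydrogen does not always produce a step beyond the scatter. Nothing measured here offers an explanation for this flat result.

The compounds shown leave open whether a larger group at this same position, such as a methoxy group or an amine, would move the number when the other fluoro groups stay in place. They also leave open how many of those remaining fluoro groups could be replaced with hydrogen before the number changes beyond the scatter.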